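Swapping the benzyl substituent in a purine series

A few compounds are considered here, and "the series" means these few. Any claim that something is new, unique, unknown or untested is made for them only; others in the source may bear on it.

Measured so far:
- compound 1, `NC1CCC(Nc2nc(NCc3ccc(-c4ccsc4)cc3)c3ncn(C4CCCC4)c3n2)CC1`: 220 nM
- compound 2, `NC1CCC(Nc2nc(NCc3ccc(-n4cccn4)cc3)c3ncn(C4CCCC4)c3n2)CC1`: 170 nM

Both numbers come from a functional assay on HeLa cells (Homo sapiens) for inhibition, with a stated time of 72 h; a lower number here means a stronger inhibitor, a higher number a weaker inhibitor. Compound 1 and compound 2 share one core and differ only in the group on the benzyl ring; the step of a 1.3-fold lower number from compound 1 to compound 2 (0.11 log units; within the scatter) separates them, so the two numbers sit within the scatter of each other and neither compound can be called the stronger.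

Compound 3, `NC1CCC(Nc2nc(NCc3cc(Cl)ccc3O)c3ncn(C4CCCC4)c3n2)CC1`, has not been measured. It changes compound 2 at the same benzyl position: 5-chloro-2-hydroxyphenyl in place of 4-(1H-pyrazol-1-yl)phenyl on a saturated chain carbon bound to a nitrogen on an aromatic ring. Going by the values given here, the only measured step concerns a different swap on that ring, so it gives no direct guide here; it shows merely that one exchange of the aromatic substituent left this assay unchanged. Compound 3 is therefore expected to land near compound 2, with a wide range because the entering group is smaller and carries a hydroxyl: the expected step is a 1.8-fold higher number from compound 2 to compound 3 (0.25 log units; within the scatter). The estimate for compound 3 in this assay is 300 nM, between 80 nM and 1500 nM.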

Compound 3, half-maximal inhibitory concentration: 750 nM
Compound 3: middle estimate off by 2.5-fold (0.40 log units), on the low side, within the range that was stated.
By their numbers in this assay, from the lowest: compounds 2 and 1 (each within the scatter of the next); then compound 3.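

In this assay, going by these compounds alone, the earlier pair showed only that exchanging one group on the benzyl ring left the number within the scatter. Replacing the whole aryl group does more: 5-chloro-2-hydroxyphenyl in place of 4-(1H-pyrazol-1-yl)phenyl gives a 4.4-fold higher number from compound 2 to compound 3 (0.64 log units; beyond the scatter) and in place of 4-(thiophen-3-yl)phenyl gives a 3.4-fold higher number from compound 1 to compound 3 (0.53 log units; beyond the scatter) on the shared core, so both steps run the same way and this position is not indifferent to what sits on it. No evidence is available on why the number rises.

The entering group differs from both leaving groups in several ways at once, losing a ring and gaining a hydroxyl and a chlorine, and these compounds cannot separate those changes. They also leave open how a plain phenyl or a 5-chloro-2-methoxyphenyl group would behave here.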